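A Methyl on the Fused Ring of Compound 1

The compounds below may be only part of what the source reports. "The series", "measured", "known", "first", "only" and "open" are said of these compounds alone.

Compound 1, `CC1CCN(c2c(S(=O)(=O)c3ccccc3)cnc3ccccc23)CC1`, gives 89.2% in an assay on isolated protein for displacement of a labelled ligand from metabotropic glutamate receptor 5 (Homo sapiens), with a stated time of 60 min, tested at 1 uM (a higher number here means more inhibition at the concentration tested (going by the name of the read-out), a lower number less inhibition), the higher of the two numbers measured, while compound 2, `CN1CCN(c2c(S(=O)(=O)c3ccccc3)cnc3ccccc23)CC1`, gives 7.7%. Within the data shown here, the only measured step, a number 81.5 percentage points lower from compound 1 to compound 2 (beyond the scatter), concerns the amine ring and not the fused system. Compound 3, `Cc1ccc2ncc(S(=O)(=O)c3ccccc3)c(N3CCC(C)CC3)c2c1`, differs from compound 1 by methyl in place of hydrogen on an aromatic carbon. Among the measured compounds shown here, no measured step touches this part of the core, so the expectation rests on compound 1 alone, anchored by its 89.2%, and the expected step of a number 7.2 percentage points lower from compound 1 to compound 3 (within the scatter) is none beyond the scatter. Compound 3 is therefore estimated at 82%, within a range from 55% to 97%.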

Compound 3, a percentage reported as inhibition, at one concentration (the size of the read-out at that concentration, not a potency): 67%
Beside the measured number, compound 3's estimate is 15 percentage points above it; low and high end bracket the measured number.
By their numbers in this assay, from the lowest: compound 2; then compound 3; then compound 1.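

In this assay, methyl in place of hydrogen on an aromatic carbon gives a number 22.2 percentage points lower from compound 1 to compound 3 (beyond the scatter) and thus shows that this part of the core, and not only the amine ring, affects the read-out. A single methyl, meta to a fused ring and para to a fused ring, is enough to carry the number beyond the scatter. Nothing available explains this loss. The compounds shown leave open how a methoxy group or a chlorine atom would read on this same carbon. They also leave open whether methyl on another carbon of that ring would give a similar step.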